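Amide nitrogen methylation on two cores: working notes

The source may hold more compounds than are shown below. What is called first, only, known or untested is meant among the compounds shown, and "the series" means these compounds.

compound 1 `CN1C/C(=C\c2ccc(Cl)cc2)C(=O)[C@]2(C1)[C@@H](c1ccc(Cl)cc1)CN(C)[C@@]21C(=O)Nc2ccccc21` — 63%
compound 2 `CN1C/C(=C\c2ccc(Cl)cc2)C(=O)[C@]2(C1)[C@@H](c1ccc(Cl)cc1)CN(C)[C@@]21C(=O)N(C)c2ccccc21` — 62.2%
compound 3 `Cc1ccc(/C=C2\CN(C)C[C@@]3(C2=O)[C@@H](c2ccc(C)cc2)CN(C)[C@@]32C(=O)Nc3ccccc32)cc1` — 52.1%

In a functional assay on the whole organism (strain Wister albino) for inhibition, with Rattus norvegicus as the target, read by paw edema, with stated times of 1 h and 2 h, at a dose of 50 mg/kg by the intraperitoneal route (a lower number here means less inhibition, a higher number more inhibition at the dose given (going by the name of the read-out)), compound 1 gives 63% and compound 2 gives 62.2%; the two numbers lie within the scatter of each other, so no order is read from them. The change from compound 1 to compound 2 is methyl in place of hydrogen on an amide-type nitrogen in a ring and the step is a number 0.8 percentage points lower from compound 1 to compound 2 (within the scatter). Compound 3 carries a different core; how it differs from compound 1 is not broken down here. In this assay compound 3 gives 52.1%, the lowest of the three numbers and beyond the scatter from both others. Compound 4 `Cc1ccc(/C=C2\CN(C)C[C@@]3(C2=O)[C@@H](c2ccc(C)cc2)CN(C)[C@@]32C(=O)N(C)c3ccccc32)cc1` is not yet measured. It differs from compound 3 by methyl in place of hydrogen on an amide-type nitrogen in a ring, the same change at the same place as between compound 1 and compound 2. For compound 4 the expected step is a number 0.1 percentage points lower from compound 3 to compound 4 (within the scatter) because a number 0.8 percentage points lower from compound 1 to compound 2 (within the scatter). A single pair is a thin basis, so the range is kept wide. Compound 4 is estimated at 52%, between 41% and 62%.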

Compound 4, a percentage reported as inhibition, in the whole organism at one dose (the size of the read-out at that dose, not a potency): 62%
For compound 4 the middle estimate is 10 percentage points below the measured one; low and high end bracket the measured number.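

In this assay, methyl in place of hydrogen on the amide-type nitrogen in a ring gives a step of a number 9.9 percentage points higher from compound 3 to compound 4 (within the scatter), so on this other core too the step stays within the usual scatter. Set beside the earlier step, it cannot be told apart: the same change on two cores in this assay, a number 0.8 percentage points lower (within the scatter) from compound 1 to compound 2 and a number 9.9 percentage points higher (within the scatter) from compound 3 to compound 4, 10.7 percentage points apart, within the scatter of two such steps. Within the data shown here, this supports carrying the change between these two cores without a readable step, but with only two pairs it does not show that the change is without effect, or that it would behave the same way on any further core.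

The compounds shown leave open how a group larger than methyl on this nitrogen would read, such as benzyl or a longer chain ending in an amine.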